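A few compounds are considered here, and "the series" means these few. Any claim that something is new, unique, unknown or untested is made for them only; others in the source may bear on it.

Two members of the series are in hand. Compound 1 `COc1cc(Cl)cc(-c2nn(-c3cccc(NC(=O)Nc4ccc(Cl)c(C(F)(F)F)c4)c3)cc2-c2ccncc2)c1` carries a urea link to the aryl ring; compound 2 `COc1cc(Cl)cc(-c2nn(-c3cccc(NC(=O)c4cc(C(F)(F)F)cc(C(F)(F)F)c4)c3)cc2-c2ccncc2)c1` carries an amide in its place. In a functional assay on DU-145 cells (Homo sapiens) for inhibition, read by sulforhodamine B assay, with a stated time of 48 h, tested at 10 uM (on this read-out lower numbers stand for a stronger effect and higher numbers for a weaker effect at the one concentration tested), compound 1 gives 15.2%, while compound 2 gives 78.2%, the higher of the two numbers and a gap beyond the scatter, so compound 2 is the weaker of the pair on this read-out.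

The next step leaves the amide in place and trims the acyl ring: compound 3 `COc1cc(Cl)cc(-c2nn(-c3cccc(NC(=O)c4cccc(C(F)(F)F)c4)c3)cc2-c2ccncc2)c1` differs from compound 2 by hydrogen in place of trifluoromethyl on an aromatic carbon, so a single trifluoromethyl remains on that ring. Among the compounds with values here, no measured pair shows a step of this kind, so the size of the step can only be guessed; with one trifluoromethyl still present and the amide unchanged, the expectation is for no step beyond the scatter, and if anything a small drift toward a slightly higher number, the step from compound 2 to compound 3 in this assay being estimated at a number 1.8 percentage points higher from compound 2 to compound 3 (within the scatter). Compound 3 is accordingly expected to give 80% in this assay, within a range of 60% to 98%.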

Compound 3, a percentage reported as activity, at one concentration (the size of the read-out at that concentration, not a potency): 83.8%
The estimate for compound 3 lay 3.8 percentage points below the measured number; the range from low to high includes it.
By their numbers in this assay, from the lowest: compound 1; then compounds 2 and 3 (each within the scatter of the next).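

In this assay, within the data shown here, hydrogen in place of trifluoromethyl on the aromatic carbon of the acyl ring gives a number 5.6 percentage points higher from compound 2 to compound 3 (within the scatter) and so does not separate the two amides: at this place, meta to a trifluoromethyl group, the read-out shows no step for losing one of the two trifluoromethyl groups. With 3-(trifluoromethyl)phenyl in place of (4-chloro-3-(trifluoromethyl)phenyl)amino on the carbonyl carbon, the series now has a one-place comparison of urea and amide, which gives a number 68.6 percentage points higher from compound 1 to compound 3 (beyond the scatter) and ties the large gap to that single change. Nothing measured here bears on why one step is large and the other lies within the scatter.

The second step changes the linking amino group and the chloro substituent together, so the compounds shown do not divide it between the two. Also open, as far as these compounds go, is whether a nitrile or a carboxylic acid in place of the remaining trifluoromethyl would leave the read-out where it stands, and whether the urea link would keep its effect with a ring carrying no chlorine.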